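The source may report more compounds than this note shows. Statements on the series, on what has been measured and on what is new or still open speak of the compounds shown alone.

Measured compounds:
Compound 1 `COc1ccc(S(=O)(=O)N2CCc3cccc(-c4ccc(O)cc4)c32)cc1` — 133 nM
Compound 2 `COc1ccc(S(=O)(=O)N2CCc3cccc(-c4cccs4)c32)cc1` — 200 nM

In a functional assay on HT-29 cells (Homo sapiens) for inhibition, with a stated time of 72 h (on this read-out lower numbers stand for stronger inhibition and higher numbers for weaker inhibition), compound 1 gives 133 nM. Compound 2 gives 200 nM, and the step of a 1.5-fold higher number from compound 1 to compound 2 (0.18 log units; within the scatter) lies within the scatter, so the two compounds stand level on the numbers shown; compound 1 cannot be called the more potent of the pair.

Compound 3 `COc1ccc(S(=O)(=O)N2CCc3cccc(-c4ccccc4)c32)cc1` differs from compound 1 by hydrogen in place of hydroxy on an aromatic carbon. Going by the values given here, no measured pair separates the hydroxy alone from the rest of the 4-hydroxyphenyl group. Among the compounds with values here, the only step available, from compound 1 to compound 2, exchanges the whole 4-hydroxyphenyl for thiophen-2-yl and still stays within the scatter, which shows that this part of the shared core tolerates at least one substantial exchange without a visible shift in this assay. Removing the hydroxy is a smaller edit than that exchange, so no step beyond the scatter is expected here in either direction.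

Compound 3 is therefore estimated at 150 nM, with a range from 70 nM to 320 nM. This estimate corresponds to an expected step of a 1.1-fold higher number from compound 1 to compound 3 (0.05 log units; within the scatter).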

Compound 3, half-maximal inhibitory concentration: 96.5 nM
For compound 3 the middle estimate is 1.6-fold (0.19 log units) above the measured one, within the range that was stated.
By their numbers in this assay, from the lowest: compounds 3, 1 and 2 (each within the scatter of the next, the first and the last beyond it).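

In this assay the hydroxy can now be read on its own: the step of a 1.4-fold lower number from compound 1 to compound 3 (0.14 log units; within the scatter) stays within the scatter, so exchanging hydroxy for hydrogen, para to a large group, brings no visible shift. The exchange of thiophen-2-yl for phenyl gives the only step among these three compounds that lies beyond the scatter, a 2.1-fold lower number from compound 2 to compound 3 (0.32 log units; beyond the scatter) and this step is modest in size. Compound 1 stays within the scatter of both compound 2 and compound 3, so the position still tolerates these exchanges, and only the two compounds without the hydroxy can be told apart.

As far as these compounds go, whether an amine or a carboxylic acid in place of the hydroxy would leave the number level with compound 3 remains open. It is also open whether a morpholine in place of the whole aromatic group would keep the number in the same region, since every compound shown carries an aromatic ring there.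

No evidence is available that would explain these numbers.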